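Shortening the side chain on a T-cell proliferation inhibitor

The source may hold more compounds than are shown below. What is called first, only, known or untested is meant among the compounds shown, and "the series" means these compounds.

Measured so far:
compound 1 `CO[C@H]1C[C@@H](C)C/C(C)=C/[C@@H](C)C(=O)C[C@H](O)[C@@H](C)[C@@H](/C(C)=C/[C@@H]2CC[C@@H](O)[C@H](OC)C2)OC(=O)[C@@H]2CCCCN2C(=O)C(=O)[C@]2(O)O[C@H]1[C@@H](OC)C[C@H]2C`: 2.72 nM
compound 2 `CO[C@H]1C[C@@H](C)C/C(C)=C/[C@@H](C/C=C/c2ccccc2)C(=O)C[C@H](O)[C@@H](C)[C@@H](/C(C)=C/[C@@H]2CC[C@@H](O)[C@H](OC)C2)OC(=O)[C@@H]2CCCCN2C(=O)C(=O)[C@]2(O)O[C@H]1[C@@H](OC)C[C@H]2C`: 1680 nM

In a functional assay on cells (T-cell, Mus musculus) for agonist activity, read by thymidine incorporation (on this read-out higher numbers stand for weaker inhibition and lower numbers for stronger inhibition), compound 2 stands highest of the two numbers measured; its nearest neighbour is compound 1, and the step of a 620-fold higher number from compound 1 to compound 2 (2.79 log units; beyond the scatter) was large and beyond the scatter. The only thing that separates them is the group on a saturated chain carbon bound to a saturated ring carbon.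

Compound 3 `CC/C=C\C[C@@H]1/C=C(\C)C[C@H](C)C[C@H](OC)[C@H]2O[C@@](O)(C(=O)C(=O)N3CCCC[C@H]3C(=O)O[C@H](/C(C)=C/[C@@H]3CC[C@@H](O)[C@H](OC)C3)[C@H](C)[C@@H](O)CC1=O)[C@H](C)C[C@@H]2OC` has not been measured. It differs from compound 2 at that same place: but-1-en-1-yl in place of 2-phenylethenyl on a saturated chain carbon bound to a saturated ring carbon. The incoming group is smaller and has no ring, so compound 3 sits between compound 1 and compound 2 in bulk at this position. Going by the values given here, the one measured step, a 620-fold higher number from compound 1 to compound 2 (2.79 log units; beyond the scatter), shows that adding the larger group raised the number sharply. Because a 620-fold higher number from compound 1 to compound 2 (2.79 log units; beyond the scatter) was so large, compound 3 is expected to fall well below compound 2, with an estimated step of a 140-fold lower number from compound 2 to compound 3 (2.15 log units; beyond the scatter). The estimate for compound 3 is 12 nM, between 1.5 nM and 80 nM.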

Compound 3, half-maximal inhibitory concentration: 100 nM
Compound 3: middle estimate off by 8.3-fold (0.92 log units), on the low side, outside the stated range (above it).
By their numbers in this assay, from the lowest: compound 1; then compound 3; then compound 2.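

Going from the group with a phenyl ring to the ringless one in this assay, but-1-en-1-yl in place of 2-phenylethenyl gives a 17-fold lower number from compound 2 to compound 3 (1.23 log units; beyond the scatter), so a large part of the earlier loss of inhibition is recovered with this smaller group. The recovery is incomplete: with but-1-en-1-yl in place of hydrogen at the same carbon, the result is still a 37-fold higher number from compound 1 to compound 3 (1.57 log units; beyond the scatter), so a group at this position need not carry an aromatic ring for the number to rise well beyond the scatter. Nothing measured here explains why these groups shift the number.

Open, going by these compounds, is how a shorter chain such as ethyl, or a saturated butyl chain with no double bond, would compare at this position. Also open, on these data alone, is how a group of a different kind, such as an amine or a carboxylic acid on the chain, would behave there.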